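Fluoro to Methoxy on the Aromatic Ring of Compound 2

This account rests on a few compounds, and the source may have more. Where it says the series, first, only, none or still open, it means among the compounds named here.

compound 1, `O=C(CCC(=O)c1cccs1)NCCCO`: > 300 mg/kg
compound 2, `O=C1CCC2(c3ccc(F)cc3)OCCCN12`: 68.7 mg/kg

In a functional assay on the whole organism with Mus musculus as the target, in the maximal electroshock model (a lower number here means that less compound is needed, a higher number that more compound is needed for the effect), compound 1, `O=C(CCC(=O)c1cccs1)NCCCO`, reaches only a limit, > 300 mg/kg. For the measured compounds named here, compound 2, `O=C1CCC2(c3ccc(F)cc3)OCCCN12`, gives 68.7 mg/kg in this assay, the only number among the two values shown, the other being (the limit of > 300 mg/kg in this assay, at which 1 of the 2 values shown sits). Compound 3, `COc1ccc(C23CCC(=O)N2CCCO3)cc1`, differs from compound 2 by methoxy in place of fluoro on an aromatic carbon. Going by the values given here, no measured pair shows the size of such a change, so no step beyond the usual scatter is expected in either direction. Compound 3 is estimated at 80 mg/kg (range 35 mg/kg to 200 mg/kg) in this assay. The expected step is a 1.2-fold higher number from compound 2 to compound 3 (0.07 log units; within the scatter).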

Compound 3, dose for half-maximal effect: 93.8 mg/kg
For compound 3 the middle estimate is 1.2-fold (0.07 log units) below the measured one; the range from low to high includes it.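

Methoxy in place of fluoro on this aromatic carbon, para to a large group, gives a 1.4-fold higher number from compound 2 to compound 3 (0.14 log units; within the scatter) in this assay. This first measured pair at the position shows that it accepts methoxy as well as fluoro, with no step beyond the scatter. Nothing shown here bears on why the two groups read alike.

From the compounds shown here alone, how an amine, a carboxylic acid or a longer chain such as butoxy would read at this carbon remains open. Going by these compounds, whether methoxy reads the same on other carbons of the ring is also open.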